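The source may hold more compounds than are shown below. What is called first, only, known or untested is meant among the compounds shown, and "the series" means these compounds.

Of the compounds shown here, three sharing one core have been measured so far in a functional assay on SiHa cells (Homo sapiens) for antiproliferative activity, read by CCK-8 assay, with a stated time of 72 h; on this read-out higher numbers stand for weaker inhibition and lower numbers for stronger inhibition. Compound 1 (`COc1ccc(-c2cncnc2-c2cc(OC)c(OC)c(OC)c2)cc1`) stands at 2850 nM and compound 2 (`COc1ccc(-c2cncnc2-c2cc(OC)c(OC)c(OC)c2)cc1F`) at 3340 nM with fluoro added, and a 1.2-fold higher number from compound 1 to compound 2 (0.07 log units; within the scatter) stays within the scatter. Compound 3 (`COc1cc(-c2ncncc2-c2ccc(SC)cc2)cc(OC)c1OC`) is the strongest of the three at 560 nM on these numbers, with a 5.1-fold lower number from compound 1 to compound 3 (0.71 log units; beyond the scatter) for methylsulfanyl in place of methoxy and a 6.0-fold lower number from compound 2 to compound 3 (0.78 log units; beyond the scatter) for 4-(methylsulfanyl)phenyl in place of 3-fluoro-4-methoxyphenyl. Compound 4 (`CCOc1ccc(-c2cncnc2-c2cc(OC)c(OC)c(OC)c2)cc1`) has ethoxy in place of methylsulfanyl on an aromatic carbon. Within the data shown here, no compound with ethoxy has been measured, so the closest guide is a 5.1-fold lower number from compound 1 to compound 3 (0.71 log units; beyond the scatter) read in reverse. Giving up methylsulfanyl should therefore raise the number, though ethoxy may not go all the way back to the methoxy level. In this assay the expected size is a 2.7-fold higher number from compound 3 to compound 4 (0.43 log units; beyond the scatter) and this modest rise is only an estimate. For compound 4 the estimated value is 1500 nM with an expected range from 500 nM to 4500 nM in a repeat measurement.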

Compound 4, half-maximal inhibitory concentration: 640 nM
Estimate against measurement, compound 4: 2.3-fold (0.37 log units) above; the measured number falls inside the stated range.
By their numbers in this assay, from the lowest: compounds 3 and 4 (each within the scatter of the next); then compounds 1 and 2 (each within the scatter of the next).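

In this assay there is a 1.1-fold higher number from compound 3 to compound 4 (0.06 log units; within the scatter) for ethoxy in place of methylsulfanyl, so on these numbers the two groups cannot be told apart at this place, para to a large group, and the sulfur of compound 3 is not needed for a low number. One added methyl on the oxygen is enough to separate ethoxy from methoxy, with a 4.5-fold lower number from compound 1 to compound 4 (0.65 log units; beyond the scatter) beyond the scatter, and a 5.2-fold lower number from compound 2 to compound 4 (0.72 log units; beyond the scatter) is also beyond the scatter for 4-ethoxyphenyl in place of 3-fluoro-4-methoxyphenyl. Nothing in the data explains why these groups give lower numbers than methoxy.

On these data alone, whether a longer chain such as propoxy or a branched isopropoxy would hold the number at this level remains open. So does the outcome with an amine such as dimethylamino at the same place.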